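The source may report more compounds than this note shows. Statements on the series, on what has been measured and on what is new or still open speak of the compounds shown alone.

For the measured compounds named here, compound 2, `COc1ccc2c(c1)CCC2NC(=O)Nc1cccc2[nH]ncc12`, gives 40 nM in an assay on isolated protein for inhibition of transient receptor potential cation channel subfamily V member 1 (Homo sapiens), read by calcium flux (on this read-out lower numbers stand for stronger inhibition and higher numbers for weaker inhibition), the lowest of the two numbers so far; its nearest neighbour, compound 1, `O=C(Nc1cccc2[nH]ncc12)NC1CCc2ccccc21`, gives 151 nM in this assay. Going by the values given here, the only measured step, a 3.8-fold lower number from compound 1 to compound 2 (0.58 log units; beyond the scatter), shows that the aromatic position now in question tolerates a substituent and rewards one. Compound 3, `O=C(Nc1cccc2[nH]ncc12)NC1CCc2cc(C(F)(F)F)ccc21`, differs from compound 2 by trifluoromethyl in place of methoxy on an aromatic carbon. No measured step exchanges one substituent for another at that carbon, so the comparison with compound 1 bears on it only indirectly: a group there helped once, but whether trifluoromethyl matches methoxy is not shown. The expected step from compound 2 to compound 3 is therefore a 1.5-fold higher number from compound 2 to compound 3 (0.18 log units; within the scatter), a change not clearly beyond the scatter. For compound 3 the estimate in this assay is 60 nM, with a range from 15 nM to 250 nM.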

Compound 3, half-maximal inhibitory concentration: 3 nM
Compound 3: middle estimate off by 20-fold (1.30 log units), on the high side; the whole stated range lies above it.
By their numbers in this assay, from the lowest: compound 3; then compound 2; then compound 1.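

For the compounds shown here, the position is more demanding than the earlier compounds showed: the identity of the group on this aromatic carbon matters, not just the presence of one, since in this assay replacing methoxy with trifluoromethyl gives a 13-fold lower number from compound 2 to compound 3 (1.12 log units; beyond the scatter). Set against the unsubstituted parent, trifluoromethyl gives a 50-fold lower number from compound 1 to compound 3 (1.70 log units; beyond the scatter), a large step where methoxy gave only a modest one, a 3.8-fold lower number from compound 1 to compound 2 (0.58 log units; beyond the scatter), so the two groups are far from interchangeable at this carbon. No measurement available here accounts for the difference between the two groups.

The compounds shown leave open how a chlorine atom, a nitrile or a tert-butyl group on this same carbon would compare with trifluoromethyl. They also leave open whether trifluoromethyl would give a comparable step on another carbon of the same ring.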